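The source may hold more compounds than are shown below. What is called first, only, known or untested is meant among the compounds shown, and "the series" means these compounds.

Series notes. Compound 1 `O=C(CSc1nnc(-c2ccncc2)o1)N/N=C/c1ccccc1`, compound 2 `O=C(CSc1nnc(-c2ccncc2)o1)N/N=C/c1ccc(Cl)cc1` and compound 3 `O=C(CSc1nnc(-c2ccncc2)o1)N/N=C/c1ccc([N+](=O)[O-])cc1` share one core and differ only in the substituent on the benzylidene ring. In an ADME assay on NIH3T3 cells (Mus musculus) for cytotoxicity, read by MTT assay, with a stated time of 24 h (a lower number here means a stronger inhibitor, a higher number a weaker inhibitor), compound 1 gives 167000 nM, compound 2 gives 181000 nM and compound 3 gives 195000 nM; compound 1 has the lowest of the three numbers, but its steps to both neighbours are within the scatter: a 1.1-fold higher number from compound 1 to compound 2 (0.03 log units; within the scatter) and a 1.2-fold higher number from compound 1 to compound 3 (0.07 log units; within the scatter).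

Compound 4 `O=C(CSc1nnc(-c2ccncc2)o1)N/N=C/c1ccccc1F`, not yet measured, differs from compound 1 by fluoro in place of hydrogen on an aromatic carbon; cut one bond further out, this reads phenyl to 2-fluorophenyl. The two measured ring substitutions, chloro and nitro, left this assay unmoved, so a fluoro substitution is expected to give no step beyond the scatter, a 1.0-fold higher number from compound 1 to compound 4 (0.02 log units; within the scatter). Compound 4 is therefore estimated at 175000 nM, range 105000 nM to 290000 nM.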

Compound 4, half-maximal inhibitory concentration: 142000 nM
For compound 4 the middle estimate is 1.2-fold (0.09 log units) above the measured one, within the range that was stated.
By their numbers in this assay, from the lowest: compounds 4, 1, 2 and 3 (each within the scatter of the next).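

In this assay, the step of a 1.2-fold lower number from compound 1 to compound 4 (0.07 log units; within the scatter) shows that fluoro ortho to a large group stays within the scatter, so this ring place joins the chloro and nitro substitutions in leaving the number unmoved. The steps of a 1.4-fold lower number from compound 3 to compound 4 (0.14 log units; within the scatter) and a 1.3-fold lower number from compound 2 to compound 4 (0.11 log units; within the scatter) also stay within the scatter, so all four compounds remain indistinguishable in this assay. Nothing available explains why these numbers lie so close.

Still open, from the compounds shown here alone, is whether an amine or a carboxylic acid on this ring gives a step beyond the scatter, and whether any change to the shared core does.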